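Pyridine to pyrimidine on the amine of a nitrile-bearing core

The compounds below may be only part of what the source reports. "The series", "measured", "known", "first", "only" and "open" are said of these compounds alone.

Compound 1 `C[C@@H](Cn1ccc(-c2ccc(C#N)c(Cl)c2)n1)Nc1cccnc1`: > 30000 nM
Compound 2 `C[C@@H](Cn1ccc(-c2ccc(C#N)c(Cl)c2)n1)Nc1ccccn1`: "not determined" (no result reported)

In a functional assay on VCaP cells (Homo sapiens) for antiproliferative activity, read by CCK-8 assay, with a stated time of 6 days (a higher number here means a weaker inhibitor, a lower number a stronger inhibitor), compound 1 reaches only a limit of the assay, > 30000 nM, not a number. For the measured compounds named here, for compound 2 this assay gives no result at all, "not determined" (no result reported), so compound 2 stands without a number of its own, and the only value shown among the two is the limit of > 30000 nM in this assay, at which 1 of the 2 values shown sits. Compound 3 `C[C@@H](Cn1ccc(-c2ccc(C#N)c(Cl)c2)n1)Nc1cncnc1` differs from compound 2 in one place: pyrimidin-5-yl in place of pyridin-2-yl on an amine nitrogen. Going by the values given here, with no step between measured compounds to lean on, the expectation is that this change brings no step beyond the usual scatter of this assay, and that compound 3 sits near the limit seen for compound 1 > 30000 nM. For compound 3 the estimated value in this assay is 25000 nM, expected to fall between 4000 nM and 30000 nM.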

Compound 3, half-maximal inhibitory concentration: > 30000 nM
Compound 3 gave a limit, no number; the forecaster's own chance of this, stated with the estimate: 60%; middle value at least 1.2-fold (0.07 log units) away from the limit.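

No step from compound 1 to compound 3 can be read in this assay, since each compound gives a limit and not a number: the limit of > 30000 nM in this assay, at which 2 of the 3 values shown sit.

As far as these compounds go, whether pyrimidin-5-yl and pyridin-3-yl differ at all on the amine nitrogen stays open, as does where compound 2 stands.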